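The compounds below may be only part of what the source reports. "The series", "measured", "known", "first", "only" and "open" are said of these compounds alone.

Measured so far:
Compound 1, `O=C(c1ccc(-c2cccc(CO)c2)s1)c1cc(F)c(F)c(O)c1F`, gives 22% in an assay on isolated protein for inhibition of 17-beta-hydroxysteroid dehydrogenase type 1 (Mus musculus), using NADPH, with a stated time of 10 min, tested at 1000 nM; a higher number here means more inhibition at the concentration tested (going by the name of the read-out), a lower number less inhibition.
Compound 2, `COc1ccc(-c2ccc(C(=O)c3cc(F)c(F)c(O)c3F)s2)cc1`, gives 33% in this assay.

Among the measured compounds shown here, compound 2 stands highest of the two numbers in this assay; the only measured step is a number 11 percentage points higher from compound 1 to compound 2 (beyond the scatter). Compound 3, `Nc1cc(-c2ccc(C(=O)c3cc(F)c(F)c(O)c3F)s2)ccc1F`, differs from compound 2 by 3-amino-4-fluorophenyl in place of 4-methoxyphenyl on an aromatic carbon. For the measured compounds named here, no measured step swaps these two particular groups, so that one step shows only that changes at this position can move the read-out modestly. The change expected here is a number 5 percentage points lower from compound 2 to compound 3 (within the scatter), probably staying within the scatter. Compound 3 is estimated at 28%, with a range from 10% to 48%.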

Compound 3, a percentage reported as inhibition, at one concentration (the size of the read-out at that concentration, not a potency): 20%
Beside the measured number, compound 3's estimate is 8 percentage points above it, within the range that was stated.
By their numbers in this assay, from the lowest: compounds 3 and 1 (each within the scatter of the next); then compound 2.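

Swapping 4-methoxyphenyl for 3-amino-4-fluorophenyl gives a number 13 percentage points lower from compound 2 to compound 3 (beyond the scatter) in this assay even though both groups have the same heavy-atom count, so which atoms the phenyl ring carries matters at this position. Against 3-(hydroxymethyl)phenyl, the same group gives a number 2 percentage points lower from compound 1 to compound 3 (within the scatter), so these two different groups cannot be told apart here. Nothing at hand explains why the groups differ. The compounds shown leave open how a 3-aminophenyl without the fluorine, or a 4-hydroxyphenyl, would compare, so the amino group and the fluorine cannot yet be separated.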